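Notes on replacing 3,4-dimethoxyphenyl with 4-methylpiperazin-1-yl

The source may hold more compounds than are shown below. What is called first, only, known or untested is meant among the compounds shown, and "the series" means these compounds.

Measured in a functional assay on MDA-MB-231 cells (Homo sapiens) for inhibition, read by MTT assay, with a stated time of 72 h; on this read-out higher numbers stand for weaker inhibition and lower numbers for stronger inhibition:
- compound 1 `CC(C)(C)n1cc2c(n1)C(=O)CC1(CCN(C(=O)c3cc(-c4ccc(Br)cc4)nc4ccccc34)CC1)O2`: > 10000 nM, a limit
- compound 2 `COc1ccc(-c2cc(C(=O)N3CCC4(CC3)CC(=O)c3nn(C(C)(C)C)cc3O4)c3ccccc3n2)cc1`: > 10000 nM, a limit
- compound 3 `COc1ccc(-c2cc(C(=O)N3CCC4(CC3)CC(=O)c3nn(C(C)(C)C)cc3O4)c3ccccc3n2)cc1OC`: 7130 nM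

Going by the values given here, compound 3 gives 7130 nM, the only true number. The rest of the set stands at the limit of > 10000 nM in this assay, at which 2 of the 3 values shown sit.

Compound 4 `CN1CCN(c2cc(C(=O)N3CCC4(CC3)CC(=O)c3nn(C(C)(C)C)cc3O4)c3ccccc3n2)CC1` carries 4-methylpiperazin-1-yl in place of 3,4-dimethoxyphenyl on an aromatic carbon, next to the ring nitrogen (4-methylpiperazin-1-yl in place of 3,4-dimethoxyphenyl on an aromatic carbon).

Among the compounds with values here, three measured steps bear on this change, and all of them alter only the substituents on the phenyl group. The first is an at least 1.4-fold lower number from compound 2 to compound 3 (0.14 log units; that floor lies within the scatter). The second is an at least 1.4-fold lower number from compound 1 to compound 3 (0.14 log units; that floor lies within the scatter). The third is a step that the two limits leave unreadable from compound 1 to compound 2. None of them removes the aromatic ring from this place, so they guide the estimate only loosely. No step beyond the scatter is expected in this assay, and a result reported only as a limit is expected to be about as likely as a number. The expected step is a 1.1-fold higher number from compound 3 to compound 4 (0.05 log units; within the scatter). For compound 4 the estimate is 8000 nM, with an expected range of 2500 nM to 25000 nM.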

Compound 4, half-maximal inhibitory concentration: 8130 nM
Compound 4: the middle estimate sits 1.0-fold (0.01 log units) below what was measured; the range from low to high includes it.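

In this assay the step is a 1.1-fold higher number from compound 3 to compound 4 (0.06 log units; within the scatter) and so shows that the aromatic ring is not needed at this position: 4-methylpiperazin-1-yl, a six-membered non-aromatic ring with 2 hetero atoms, stands in for 3,4-dimethoxyphenyl with no readable change. Against the 4-methoxyphenyl and 4-bromophenyl groups only floors can be read, as an at least 1.2-fold lower number from compound 2 to compound 4 (0.08 log units; that floor lies within the scatter) and as an at least 1.2-fold lower number from compound 1 to compound 4 (0.08 log units; that floor lies within the scatter) in the same way. Neither floor shows a real difference, and both rest on a limit rather than a number: the limit of > 10000 nM in this assay, at which 2 of the 4 values shown sit.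

Going by these compounds, whether piperazin-1-yl without the methyl, morpholin-4-yl or a carboxylic acid at this position would move the number beyond the scatter stays open. Also open, on these data alone, is whether the same exchange holds with a longer chain in place of the tert-butyl group on the shared core.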